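The compounds below may be only part of what the source reports. "The series", "measured", "known", "first", "only" and "open" are said of these compounds alone.

Measured in a functional assay (blood) for inhibition, with Homo sapiens as the target; on this read-out higher numbers stand for weaker inhibition and lower numbers for stronger inhibition:
- compound 1 `CC(C)(C)Sc1c(CC(C)(C)C(=O)O)n(Cc2ccc(Cl)cc2)c2ccc(OCc3cccnc3)cc12`: > 3000 nM (a limit)
- compound 2 `CC(COc1ccc2c(c1)c(SC(C)(C)C)c(CC(C)(C)C(=O)O)n2Cc1ccc(Cl)cc1)c1ccccn1`: 270 nM

Within the data shown here, compound 2 holds the only actual number in this assay, since the entry for compound 1 is a limit. Compound 3 `CC(C)c1csc(COc2ccc3c(c2)c(SC(C)(C)C)c(CC(C)(C)C(=O)O)n3Cc2ccc(Cl)cc2)n1` is still unmeasured. It carries 4-isopropyl-1,3-thiazol-2-yl in place of 1-(pyridin-2-yl)ethyl on a saturated chain carbon bound to an oxygen on an aromatic ring. Among the measured compounds shown here, one measured step bears on this place, an at least 11-fold lower number from compound 1 to compound 2 (1.04 log units; beyond the scatter). That step was large, so the group here clearly matters, but it sets no direction for this exchange. The expected result is a 1.2-fold lower number from compound 2 to compound 3 (0.09 log units; within the scatter), with no shift beyond the scatter foreseen. For compound 3 the estimated value is 220 nM, with an expected range of 60 nM to 800 nM.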

Compound 3, half-maximal inhibitory concentration: > 3000 nM
Compound 3 was reported as a limit; the forecaster's own chance of this, stated with the estimate: 10%; middle value at least 13-fold (1.13 log units) away from the limit.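

In this assay 4-isopropyl-1,3-thiazol-2-yl in place of 1-(pyridin-2-yl)ethyl gives an at least 11-fold higher number from compound 2 to compound 3 (1.04 log units; beyond the scatter), so at this position an equal count of heavy atoms does not preserve the read-out. Compound 3 joins compound 1 at a limit rather than a number: the limit of > 3000 nM in this assay, at which 2 of the 3 values shown sit. Among these compounds, the step between those two limits cannot be read, and compound 2 remains the only compound with an actual number.

From the compounds shown here alone, it remains open whether the pyridine ring or the branched chain matters more in 1-(pyridin-2-yl)ethyl. A 1-phenylethyl group or an unbranched pyridin-2-yl group could separate the two.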